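The source may hold more compounds than are shown below. What is called first, only, known or untested is meant among the compounds shown, and "the series" means these compounds.

Working notes on the series. Two compounds of the shared core have numbers in a functional assay on CHO-K1 cells for antagonist activity at melanin-concentrating hormone receptor 1 (Homo sapiens), read by inositol phosphate accumulation, with stated times of 10 min and 45 min; on this read-out lower numbers stand for stronger inhibition and higher numbers for weaker inhibition. Compound 1 `Cc1nc(N2CCC(NS(=O)(=O)N(C)C)CC2)nc2ccc(NC(=O)/C=C/c3ccc(OC(F)(F)F)cc3)cc12` gives 31 nM in this assay. Compound 2 `CCCC1(O)CCN(c2nc(C)c3cc(NC(=O)/C=C/c4ccc(Cl)cc4)ccc3n2)CC1` gives 91 nM in this assay. Compound 1 therefore holds the lowest of the two numbers, and its gap to compound 2 lies beyond the scatter, so compound 1 is the stronger of the measured pair. Among the compounds with values here, no step between compounds that differ in a single place has been measured, so the weight of any single change cannot yet be read from the data.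

Compound 3 `Cc1nc(N2CCC(N3C(=O)CCC3=O)CC2)nc2ccc(NC(=O)/C=C/c3ccc(OC(F)(F)F)cc3)cc12` is not yet measured in this assay. It differs from compound 1 in one place: 2,5-dioxopyrrolidin-1-yl in place of (dimethylsulfamoyl)amino on a saturated ring carbon. The group that leaves carries one hydrogen-bond donor and two hydrogen-bond acceptors; the group that enters carries no hydrogen-bond donor and two hydrogen-bond acceptors, at an equal count of heavy atoms. Without a measured step of this kind, a modest move toward a higher number is expected, of the size a 1.9-fold higher number from compound 1 to compound 3 (0.29 log units; within the scatter). For compound 3 the estimated value in this assay is 60 nM, with a range from 20 nM to 180 nM.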

Compound 3, half-maximal inhibitory concentration: 35 nM
The estimate for compound 3 lay 1.7-fold (0.23 log units) above the measured number; low and high end bracket the measured number.
By their numbers in this assay, from the lowest: compounds 1 and 3 (each within the scatter of the next); then compound 2.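

Within the data shown here, the replacement of (dimethylsulfamoyl)amino by 2,5-dioxopyrrolidin-1-yl on a saturated ring carbon gives the only single-place step in this assay so far: a 1.1-fold higher number from compound 1 to compound 3 (0.05 log units; within the scatter) and the two groups cannot be told apart on this read-out. The group that leaves carries a hydrogen-bond donor and no ring, whereas the group that enters carries no donor and a five-membered non-aromatic ring, at an equal count of heavy atoms; for this pair, then, neither the donor nor the open form of the group is needed to hold a number of this size at this position. No measurement is at hand that could account for this result.

What the compounds shown leave open is whether this position holds its number with a charged or much smaller group, such as a primary amine, a carboxylic acid or a methyl group. As far as these compounds go, it is also open whether the two groups stay equivalent when the trifluoromethoxy group shared by compound 1 and compound 3 gives way to a nitrile.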